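Notes: 3-oxopiperazin-1-yl to 1,4-diazepan-1-yl on the shared core

A few compounds are considered here, and "the series" means these few. Any claim that something is new, unique, unknown or untested is made for them only; others in the source may bear on it.

In a physicochemical assay for solubility, read by HPLC, using the shake flask method, in phosphate buffer, with a stated time of 20 h, at pH 6.5 (on this read-out higher numbers stand for higher solubility and lower numbers for lower solubility), compound 1 (`O=C1CN(c2nccc3[nH]c(-c4ccc(F)c(F)c4)nc23)CCN1`) gives < 5000 nM, which is a limit of the assay and not a number. Compound 2 (`Fc1ccc(-c2nc3c(N4CCN5CCCC5C4)nccc3[nH]2)cc1F`) gives a true reading of 120000 nM in this assay. Compound 3 (`Fc1ccc(-c2nc3c(N4CCCNCC4)nccc3[nH]2)cc1F`) has not yet been measured. It carries 1,4-diazepan-1-yl in place of 3-oxopiperazin-1-yl on an aromatic carbon, next to the ring nitrogen of the shared core: 1,4-diazepan-1-yl in place of 3-oxopiperazin-1-yl on an aromatic carbon. Within the data shown here, no measured single-place step is available to size this change, so the only numeric guide is compound 2 at 120000 nM. On that basis, a rise beyond the usual scatter is expected in this assay, an estimated at least 16-fold higher number from compound 1 to compound 3 (1.20 log units; beyond the scatter). For compound 3 the expected reading is 80000 nM, with an estimated range of 20000 nM to 250000 nM.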

Compound 3, solubility: 165000 nM
Compound 3: middle estimate off by 2.1-fold (0.31 log units), on the low side; the measured number falls inside the stated range.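

In this assay, 1,4-diazepan-1-yl in place of 3-oxopiperazin-1-yl on an aromatic carbon, next to the ring nitrogen, gives an at least 33-fold higher number from compound 1 to compound 3 (1.51 log units; beyond the scatter), the only measured single-place step shown at this position. For compound 1 the reading of < 5000 nM is a limit of the assay and not a number. The step therefore fixes only a floor for the size of this change, because one of its ends rests on that limit: the limit of < 5000 nM in this assay, at which 1 of the 3 values shown sits.

This pair changes the ring size and removes the carbonyl in one move, and the two changes cannot be told apart from it. From the compounds shown here alone, a plain piperazin-1-yl in the same place, carrying no carbonyl on a six-membered ring, remains open as the group that would separate them.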